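Removing a Chloro Group on Two Related Cores

The source may report more compounds than this note shows. Statements on the series, on what has been measured and on what is new or still open speak of the compounds shown alone.

Compound 1 `N#Cc1ccc(OCc2ccsc2)cc1/C=C(/C(=O)O)c1ccccc1` and compound 2 `N#Cc1ccc(OCc2ccsc2)cc1/C=C(/C(=O)O)c1ccccc1Cl` share one core and differ in a single place: hydrogen in place of chloro on an aromatic carbon. In an assay on A10 cells for binding affinity to Endothelin-1 receptor (Rattus norvegicus) (a higher number here means a weaker inhibitor, a lower number a stronger inhibitor), compound 2 gives 200 nM, while compound 1 gives 80 nM, so that a 2.5-fold lower number from compound 2 to compound 1 (0.40 log units; beyond the scatter). Compound 3 `O=[N+]([O-])c1ccc(OCc2ccsc2)cc1/C=C(/CO)c1ccccc1Cl` is built on a different core; the difference between the two cores is not broken down here. In this assay compound 3 gives 400 nM. Compound 4 `O=[N+]([O-])c1ccc(OCc2ccsc2)cc1/C=C(/CO)c1ccccc1` has not yet been measured, and it differs from compound 3 by the same change as before, at the same kind of place: hydrogen in place of chloro on an aromatic carbon. A similar step is expected for compound 4, namely a 2.5-fold lower number from compound 3 to compound 4 (0.40 log units; beyond the scatter), because a 2.5-fold lower number from compound 2 to compound 1 (0.40 log units; beyond the scatter) shows what this change did on the other core. In this assay compound 4 is therefore estimated at 160 nM, most likely between 80 nM and 320 nM.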

Compound 4, half-maximal inhibitory concentration: 1400 nM
Compound 4: middle estimate off by 8.8-fold (0.94 log units), on the low side; the measured number lies above the stated range.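

The change did not carry over: in this assay it gives a 3.5-fold higher number from compound 3 to compound 4 (0.54 log units; beyond the scatter), opposite in direction to the step on the other core. The two steps disagree by more than scatter can explain: the same change on two cores in this assay, a 2.5-fold lower number (0.40 log units; beyond the scatter) from compound 2 to compound 1 and a 3.5-fold higher number (0.54 log units; beyond the scatter) from compound 3 to compound 4, 8.8-fold (0.94 log units) apart, beyond the scatter of two such steps. So, for these two pairs, a step measured on one core does not predict the same change on the other, although the data do not show which part of the cores makes the difference or why.

Going by these compounds alone, with only one pair on each core, it remains open how the same change would behave on a third core. On these data alone, it also remains open whether a fluoro or methyl group on the same aromatic carbon would follow the chloro compounds.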